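A few compounds are considered here, and "the series" means these few. Any claim that something is new, unique, unknown or untested is made for them only; others in the source may bear on it.

In a functional assay on MIA PaCa-2 cells (Homo sapiens) for cytotoxicity, read by trypan blue exclusion, with a stated time of 96 h (on this read-out higher numbers stand for weaker inhibition of growth and lower numbers for stronger inhibition of growth), compound 1 `COc1ccc(NS(=O)(=O)/C=C/c2c(OC)cc(OC)cc2OC)cc1` gives 100 nM, while compound 2 `COc1cc(OC)c(/C=C/S(=O)(=O)Nc2ccc(OC)c(O)c2)c(OC)c1` gives 10 nM, the lower of the two numbers. For the measured compounds named here, the only measured step, a 10-fold lower number from compound 1 to compound 2 (1.00 log units; beyond the scatter), is hydroxy in place of hydrogen on an aromatic carbon, and it lies beyond the scatter. Compound 3 `COc1cc(OC)c(/C=C/S(=O)(=O)Nc2ccc(OC)c(N)c2)c(OC)c1` alters that same carbon of compound 2: amino in place of hydroxy on an aromatic carbon. In words, this is amino in place of hydroxy on an aromatic carbon, ortho to a methoxy group.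

Going by the values given here, no measured step covers this exchange directly. The step of a 10-fold lower number from compound 1 to compound 2 (1.00 log units; beyond the scatter) bears on it only indirectly, showing that the number in this assay can respond to a change at this carbon. That step, however, replaced hydrogen, whereas here one group gives way to another. A much smaller step is therefore expected, with no firm direction and probably none beyond the scatter. The expected step is a 1.5-fold higher number from compound 2 to compound 3 (0.18 log units; within the scatter). The estimated value for compound 3 is 15 nM, with an expected range from 4 nM to 60 nM.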

Compound 3, concentration for 50% growth inhibition: 4 nM
For compound 3 the middle estimate is 3.8-fold (0.57 log units) above the measured one; the range from low to high includes it.
By their numbers in this assay, from the lowest: compound 3; then compound 2; then compound 1.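

In this assay the exchange of hydroxy for amino gives a 2.5-fold lower number from compound 2 to compound 3 (0.40 log units; beyond the scatter), which shows that the number at this carbon still responds when one substituent replaces another, and that hydroxy was not the best of the groups seen here. Measured against the hydrogen of the starting compound, amino gives a 25-fold lower number from compound 1 to compound 3 (1.40 log units; beyond the scatter), a larger step than a 10-fold lower number from compound 1 to compound 2 (1.00 log units; beyond the scatter) seen with hydroxy, so the order at this carbon among the three groups shown runs from amino through hydroxy to hydrogen, with amino giving the lowest number. Nothing measured here accounts for why amino and hydroxy differ on this carbon, although the two groups match in what is counted for them.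

As far as these compounds go, it remains open whether the number would fall further or rise again with other groups on this carbon, such as a methylamino group, an acetamido group, a fluorine or a carboxylic acid. From the compounds shown here alone, it is equally open whether the amino group would keep its advantage over hydroxy if the methoxy group were changed to an ethoxy group.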